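From 2,4,6-trimethylbenzyl to 4-isopropylbenzyl: an expected step

The source may hold more compounds than are shown below. What is called first, only, known or untested is meant among the compounds shown, and "the series" means these compounds.

Values measured in a functional assay on cells (Homo sapiens) for cytotoxicity, read by MTT assay, with a stated time of 72 h (on this read-out higher numbers stand for weaker inhibition and lower numbers for stronger inhibition), are these:
- compound 1 `Cc1ccccc1COc1cc(NC(=O)c2ccccc2)ccc1N(C)S(C)(=O)=O` gives 176000 nM
- compound 2 `Cc1cccc(COc2cc(NC(=O)c3ccccc3)ccc2N(C)S(C)(=O)=O)c1` gives 16100 nM
- compound 3 `Cc1cc(C)c(COc2cc(NC(=O)c3ccccc3)ccc2N(C)S(C)(=O)=O)c(C)c1` gives 10300 nM

Two steps place compound 3: one is large (a 17-fold lower number from compound 1 to compound 3 (1.23 log units; beyond the scatter)) and one stays within the scatter (a 1.6-fold lower number from compound 2 to compound 3 (0.19 log units; within the scatter)). Compound 4 `CC(C)c1ccc(COc2cc(NC(=O)c3ccccc3)ccc2N(C)S(C)(=O)=O)cc1` is not yet measured. It carries 4-isopropylphenyl in place of 2,4,6-trimethylphenyl on a saturated chain carbon bound to an oxygen on an aromatic ring. The steps at this place bear on it, though none brings in 4-isopropylphenyl. A third step was also large (an 11-fold lower number from compound 1 to compound 2 (1.04 log units; beyond the scatter)), so compound 1 stands apart from the other two. No step beyond the scatter is therefore expected in this assay, with some risk toward higher numbers. The estimated step is small (a 1.4-fold higher number from compound 3 to compound 4 (0.13 log units; within the scatter)). Compound 4 is estimated at 14000 nM (expected range 5000 nM to 50000 nM).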

Compound 4, half-maximal inhibitory concentration: 7930 nM
Beside the measured number, compound 4's estimate is 1.8-fold (0.25 log units) above it, and the stated range covers the measured number.
By their numbers in this assay, from the lowest: compounds 4, 3 and 2 (each within the scatter of the next, the first and the last beyond it); then compound 1.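

In this assay the 4-isopropylphenyl, with the same heavy-atom count as the 2,4,6-trimethylphenyl, shows a 1.3-fold lower number from compound 3 to compound 4 (0.11 log units; within the scatter) and so cannot be separated from it. Set against the other two groups at this place, it gives a 2.0-fold lower number from compound 2 to compound 4 (0.31 log units; beyond the scatter) as a modest step that compound 3 did not show, and a 22-fold lower number from compound 1 to compound 4 (1.35 log units; beyond the scatter) as a large step, so the 2-methylphenyl still stands apart. No measured evidence accounts for these steps.

As far as these compounds go, what a 4-methoxyphenyl, a pyridine ring or a longer chain carrying an amine would give on a saturated chain carbon bound to an oxygen on an aromatic ring remains open.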